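The compounds below may be only part of what the source reports. "The series", "measured", "known", "first", "only" and "open" are said of these compounds alone.

Measured compounds and their values in a functional assay on HCT-8 cells (Homo sapiens) for antiproliferative activity, read by MTT assay, with a stated time of 48 h; a higher number here means a weaker inhibitor, a lower number a stronger inhibitor:

Compound 1 `C=C(c1ccc(OC)cc1NC(=O)CNC)c1ccc(OC)c2c1OC(C)(C)C=C2` gives 320 nM.
Compound 2 `C=C(c1ccc2c(c1)C=CC(C)(C)O2)c1ccc(OC)cc1NC(=O)CNC` gives 590 nM.
Compound 3 `C=C(c1ccc(OC)cc1NC(=O)CNCC)c1ccc(OC)c2c1OC(C)(C)C=C2` gives 1380 nM.

Compound 1 and compound 2 carry different cores; the difference between the two cores is not broken down here. Within the scatter of this assay, the values of compound 1 and compound 2 cannot be told apart.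

Compound 3 is compound 1 with one change, (methyl in place of hydrogen on a saturated chain carbon bound to an amine nitrogen). This change gave a 4.3-fold higher number from compound 1 to compound 3 (0.63 log units; beyond the scatter), so the methyl entering on the chain carbon at the amine went with a weaker inhibitor, though the step is only modest.

Compound 4 `C=C(c1ccc2c(c1)C=CC(C)(C)O2)c1ccc(OC)cc1NC(=O)CNCC` is not yet measured. It comes from compound 2 by exactly the same change, (methyl in place of hydrogen on a saturated chain carbon bound to an amine nitrogen), made on the other core. For the measured compounds named here, only one example of this change has been measured, so the expectation for compound 4 rests on that single step.

The step from compound 2 to compound 4 is expected to be about a 3.9-fold higher number from compound 2 to compound 4 (0.59 log units; beyond the scatter), because compound 1 to compound 3 showed a 4.3-fold higher number from compound 1 to compound 3 (0.63 log units; beyond the scatter). Compound 4 is therefore estimated at 2300 nM, most likely between 900 nM and 6000 nM.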

Compound 4, half-maximal inhibitory concentration: 2220 nM
Compound 4: middle estimate off by 1.0-fold (0.02 log units), on the high side; the range from low to high includes it.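

In this assay, replacing methylamino with ethylamino on the core of compound 2 gave a 3.8-fold higher number from compound 2 to compound 4 (0.58 log units; beyond the scatter) and so went with a weaker inhibitor, as the same change did on the core of compound 1. Set side by side, the two steps cannot be told apart: the same change on two cores in this assay, a 4.3-fold higher number (0.63 log units; beyond the scatter) from compound 1 to compound 3 and a 3.8-fold higher number (0.58 log units; beyond the scatter) from compound 2 to compound 4, 1.1-fold (0.06 log units) apart, within the scatter of two such steps. For these two cores, then, the change carried over at about the same size, but two pairs are a small sample, and they show neither that it would do so on any other core nor why the added methyl goes with a weaker inhibitor.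

The compounds shown leave open how the number moves with other groups on the amine nitrogen, such as a free amino group with no chain, a propyl group or longer chain, or a ring amine such as pyrrolidine. They also leave open whether the same step would appear in other cell lines.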